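The source may hold more compounds than are shown below. What is called first, only, known or untested is meant among the compounds shown, and "the series" means these compounds.

Among the measured compounds shown here, in a functional assay on U-937 cells (Homo sapiens), read by cAMP accumulation (on this read-out higher numbers stand for weaker inhibition and lower numbers for stronger inhibition), two compounds have numbers so far: compound 1 (`COc1ccc(-c2ccc(C(N)=O)cc2)cc1O[C@H]1CC2CCC1C2`) gives 22 nM and compound 2 (`COc1ccc(-c2ccc(C(N)=O)nc2)cc1OC1CCCC1`) gives 46 nM. Compound 2 is therefore the higher number of the two and the weaker inhibitor, by a gap beyond the usual scatter. Compound 3 (`COc1ccc(-c2ccc(C(N)=O)nc2)cc1O[C@H]1CC2CCC1C2`) keeps the core of compound 2 and changes only the group on the oxygen on the aromatic ring: a group of 7 heavy atoms (7 carbon; 2 five-membered non-aromatic rings of carbon only) in place of a group of 5 heavy atoms (5 carbon; one five-membered non-aromatic ring of carbon only), on an oxygen on an aromatic ring. For the measured compounds named here, the cyclopentyl leaves, and the group that enters is the one already carried by compound 1. Going by the values given here, compounds 1 and 2 differ in more than one place, so no measured step isolates this change. Even so, with that group in place compound 1 reaches 22 nM, so a modest fall in the number is expected, only just past the scatter. The expected change is a 2.3-fold lower number from compound 2 to compound 3 (0.36 log units; beyond the scatter). For compound 3 the estimated value is 20 nM, with a likely range of 8 nM to 50 nM.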

Compound 3, half-maximal inhibitory concentration: 49 nM
For compound 3 the middle estimate is 2.5-fold (0.39 log units) below the measured one, and the stated range covers the measured number.
By their numbers in this assay, from the lowest: compound 1; then compounds 2 and 3 (each within the scatter of the next).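

Putting the two-ring group in place of cyclopentyl on this oxygen gives a 1.1-fold higher number from compound 2 to compound 3 (0.03 log units; within the scatter) in this assay, so compound 2 and compound 3 cannot be told apart. On this core, then, the position accepts both groups, and the extra carbons and second ring bring no measurable gain. The same group sits on compound 1, which gives 22 nM, while compound 3 gives 49 nM, so this group does not by itself bring the lower number: the two compounds differ elsewhere in the core.

Nothing shown explains why the two groups read alike. Also open, on these data alone, is how this oxygen responds to quite different groups, such as a small methyl, a cyclohexyl ring or a chain ending in an amine.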